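Amino for Bromo in a Weakly Cytotoxic Quinazoline Set

A few compounds are considered here, and "the series" means these few. Any claim that something is new, unique, unknown or untested is made for them only; others in the source may bear on it.

Compound 1 `Fc1cccc(Nc2nc(-c3cccc(F)c3)nc3ccc(F)cc23)c1`, compound 2 `Fc1cccc(-c2nc(Nc3ccc(Br)cc3)c3cc(F)ccc3n2)c1` and compound 3 `Fc1cccc(-c2nc(Nc3cccc(Br)c3)c3cc(F)ccc3n2)c1` share one core and differ in the aryl group on the nitrogen. In a functional assay on MCF7 cells (Homo sapiens) for cytotoxicity, read by MTT assay, with a stated time of 48 h (a lower number here means a stronger inhibitor, a higher number a weaker inhibitor), compound 1 gives 48700 nM. For compound 2 this assay reports only a limit, > 50000 nM. For compound 3 this assay likewise reports only a limit, > 50000 nM. Compound 3 thus stands at the limit of > 50000 nM in this assay, at which 2 of the 3 values shown sit. The steps of an at least 1.0-fold higher number from compound 1 to compound 2 (0.01 log units; that floor lies within the scatter) and an at least 1.0-fold higher number from compound 1 to compound 3 (0.01 log units; that floor lies within the scatter) are bounded only from below, and the step that the two limits leave unreadable from compound 2 to compound 3 cannot be read at all. Compound 4 `Nc1cccc(Nc2nc(-c3cccc(F)c3)nc3ccc(F)cc23)c1` differs from compound 3 by amino in place of bromo on an aromatic carbon. Going by the values given here, no measured step exchanges bromo for amino, and no measured step in this assay is readable beyond the scatter, so nothing seen here points to a gain or a loss. Compound 4 is therefore expected to sit near the same limit, a step of an at least 1.1-fold lower number from compound 3 to compound 4 (0.04 log units; that floor lies within the scatter), with an estimate of 45000 nM within 12000 nM to 150000 nM.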

Compound 4, half-maximal inhibitory concentration: > 50000 nM
Compound 4 gave a limit, no number (the forecaster's own chance of this, stated with the estimate: 55%); at least 1.1-fold (0.04 log units) between middle value and limit.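

In this assay compound 4 gives only a limit, so amino on this aromatic carbon joins bromo in leaving the result unresolved: the limit of > 50000 nM in this assay, at which 3 of the 4 values shown sit.

Going by these compounds alone, the only step with a bound is an at least 1.0-fold higher number from compound 1 to compound 4 (0.01 log units; that floor lies within the scatter), so amino in place of fluoro shows no readable gain or loss. The steps from compound 2 and compound 3 to compound 4 cannot be read, and the exchange of bromo for amino therefore has no measurable size here.

On these data alone, what values lie behind the limits of compound 2, compound 3 and compound 4 stays open. So does whether a hydroxyl, a methoxy or a carboxylic acid on this aromatic carbon would give a number that stands clear of the scatter.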